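A few compounds are considered here, and "the series" means these few. Any claim that something is new, unique, unknown or untested is made for them only; others in the source may bear on it.

Measured compounds in a functional assay on RPMI-8226 cells (Homo sapiens) for inhibition, read by sulforhodamine B assay, with a stated time of 48 h, tested at 1 uM; on this read-out lower numbers stand for a stronger effect and higher numbers for a weaker effect at the one concentration tested:
Compound 1 `O=C(Nc1cccc(-n2cc(-c3ccncc3)c(-c3cc(O)cc(Cl)c3)n2)c1)Nc1ccc(Cl)c(Cl)c1`: 57%
Compound 2 `COc1cc(Cl)cc(-c2nn(-c3cccc(NC(=O)Nc4ccc(Cl)c(Cl)c4)c3)cc2-c2ccncc2)c1`: 39%

Of the two numbers in this assay, compound 2 gives the lower one with 39%, while compound 1 gives 57%. Within the data shown here, the single measured step between them, a number 18 percentage points lower from compound 1 to compound 2 (beyond the scatter), arose from methyl in place of hydrogen on an oxygen on an aromatic ring and lies beyond the scatter, so compound 2 stands as the stronger of the two at the concentration tested.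

Compound 3 `COc1cc(Cl)cc(-c2nn(-c3cccc(NC(=O)c4cccc(C(F)(F)F)c4)c3)cc2-c2ccncc2)c1` differs from compound 2 in a different place: 3-(trifluoromethyl)phenyl in place of (3,4-dichlorophenyl)amino on a carbonyl carbon. Among the measured compounds shown here, no measured step touches this carbonyl carbon; the only step available concerns the oxygen on the aromatic ring and gives no guide to what a change at the carbonyl carbon does. The expectation for compound 3 therefore rests on compound 2 alone, with wide uncertainty, and the estimated step of a number 6 percentage points higher from compound 2 to compound 3 (within the scatter) is one within the scatter rather than in either direction. Compound 3 is thus estimated at 45%, with a range from 22% to 70%.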

Compound 3, a percentage reported as activity, at one concentration (the size of the read-out at that concentration, not a potency): 79%
Compound 3: the middle estimate sits 34 percentage points below what was measured; measured number above the stated range.
By their numbers in this assay, from the lowest: compound 2; then compound 1; then compound 3.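

In this assay, the carbonyl carbon turns out to be a sensitive place in this series: a number 40 percentage points higher from compound 2 to compound 3 (beyond the scatter), and this large step, the weaker direction at the one concentration tested, exceeds the modest change seen at the oxygen on the aromatic ring. The change is not a single one, since the amino nitrogen leaves along with the dichlorophenyl ring and a ring bearing trifluoromethyl enters directly on the carbonyl carbon, so this one step cannot assign the loss to the nitrogen or to the ring substituents. No measurement of any property or of any other kind bears on why the number rose, so the step stands without an explanation.

The compounds shown leave open which part of the change carries the step, a question that (3-(trifluoromethyl)phenyl)amino or a 3,4-dichlorophenyl group placed directly on the carbonyl carbon would separate. They also leave open whether the step seen on the oxygen would hold with the 3-(trifluoromethyl)phenyl group in place, or whether an ethyl group on that oxygen would go further than the methyl.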